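The source may report more compounds than this note shows. Statements on the series, on what has been measured and on what is new or still open speak of the compounds shown alone.

Working notes on the series in a functional assay on Jurkat cells (Homo sapiens) for antiproliferative activity, read by MTT assay; on this read-out lower numbers stand for stronger inhibition and higher numbers for weaker inhibition.

Compound 1 `COc1cccc(/C=C2\CCc3cc(OC)c(OC)cc3C2=O)c1` carries the shared core with a six-membered saturated ring; in this assay compound 1 gives 5000 nM. Compound 2 `COc1cc2c(cc1OC)C(=O)/C(=C/c1cccc([N+](=O)[O-])c1)CC2` keeps that core and differs from compound 1 only by nitro in place of methoxy on an aromatic carbon. In this assay compound 2 gives 9000 nM, so the change gives a 1.8-fold higher number from compound 1 to compound 2 (0.26 log units; within the scatter). Compound 3 `COc1cccc(/C=C2\Cc3cc(OC)c(OC)cc3C2=O)c1` has the smaller core; the difference between the two cores is not broken down here. In this assay compound 3 gives 12800 nM, the highest of the three numbers, beyond the scatter from compound 1 and within the scatter of compound 2.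

Compound 4 `COc1cc2c(cc1OC)C(=O)/C(=C/c1cccc([N+](=O)[O-])c1)C2` is not yet measured. It differs from compound 3 by nitro in place of methoxy on an aromatic carbon, the same change that turns compound 1 into compound 2, at the same place. That earlier step stayed within the scatter, so a comparable step is expected here, giving a 1.6-fold higher number from compound 3 to compound 4 (0.19 log units; within the scatter) from compound 3. Compound 4 is therefore estimated at 20000 nM, with the likely range from 8000 nM to 50000 nM, resting on compound 1 to compound 2 and on compound 3 at 12800 nM.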

Compound 4, half-maximal inhibitory concentration: 22000 nM
Beside the measured number, compound 4's estimate is 1.1-fold (0.04 log units) below it; measured number inside the range.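

In this assay, nitro in place of methoxy on an aromatic carbon of the smaller core gives a 1.7-fold higher number from compound 3 to compound 4 (0.24 log units; within the scatter). Set beside the same change on the core of compound 1, the two steps agree: the same change on two cores in this assay, a 1.8-fold higher number (0.26 log units; within the scatter) from compound 1 to compound 2 and a 1.7-fold higher number (0.24 log units; within the scatter) from compound 3 to compound 4, 1.0-fold (0.02 log units) apart, within the scatter of two such steps. So, for this pair of cores, the change carries over with no detectable difference in size, but each step lies within the scatter, so neither shows that nitro and methoxy differ at this place, and two cores cannot speak for any other core in the series.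

The compounds shown carry only methoxy or nitro at this place, so an amine, a carboxylic acid or a fluorine there remains open. As far as these compounds go, whether any such group would give matching steps on the two cores, or a step beyond the scatter on either, also remains open.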